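The source may hold more compounds than are shown below. What is called first, only, known or untested is meant among the compounds shown, and "the series" means these compounds.

Compound 1, `Cc1nccn1-c1csc(Nc2cccc(Br)c2)n1`, in a functional assay on RKO cells (Homo sapiens) for cytotoxicity, read by resazurin assay, with a stated time of 72 h (a higher number here means a weaker inhibitor, a lower number a stronger inhibitor), gives > 100000 nM, a limit of the assay rather than a number.
Compound 2, `Cc1cn(-c2csc(Nc3cccc(Br)c3)n2)c(C)n1`, in this assay gives > 100000 nM, likewise a limit.
Within the data shown here, compound 3, `Cc1nccn1-c1csc(Nc2ccccc2)n1`, in this assay gives 32500 nM, the only number among the three.

The three measured compounds share a core and differ at two places. Going from compound 1 to compound 3 the change is hydrogen in place of bromo on an aromatic carbon, and it gives an at least 3.0-fold lower number from compound 1 to compound 3 (0.48 log units; beyond the scatter). Going from compound 1 to compound 2 the change is methyl in place of hydrogen on an aromatic carbon, and the step is a step that the two limits leave unreadable from compound 1 to compound 2, because both values sit at the limit of > 100000 nM in this assay, at which 2 of the 3 values shown sit.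

Compound 4, `Cc1ccc(Nc2nc(-n3ccnc3C)cs2)cc1`, has not yet been measured. It differs from compound 3 by methyl in place of hydrogen on an aromatic carbon. Among the measured compounds shown here, this is the same kind of change as the one from compound 1 to compound 2, but not the same: there the methyl enters on an aromatic carbon of a five-membered aromatic ring with 2 nitrogen, next to the ring nitrogen, two ring bonds from the ring atom that bears a large group and two ring bonds from the ring atom that bears a methyl group; here it enters on an aromatic carbon of a six-membered aromatic ring of carbon only, para to a large group. The cores of the two pairs differ by hydrogen in place of bromo on an aromatic carbon.

For the measured compounds named here, since the only measured example of this kind of change gives no readable size, the step from compound 3 to compound 4 is expected to be small, about a 1.1-fold lower number from compound 3 to compound 4 (0.03 log units; within the scatter). Compound 4 is therefore estimated at 30000 nM in this assay, with a range from 10000 nM to 100000 nM.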

Compound 4, half-maximal inhibitory concentration: 450 nM
Compound 4: middle estimate off by 67-fold (1.82 log units), on the high side; measured number outside the range, below it.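

In this assay, methyl in place of hydrogen on an aromatic carbon of a six-membered aromatic ring of carbon only, para to a large group, gives a 72-fold lower number from compound 3 to compound 4 (1.86 log units; beyond the scatter), so on this core a small change at this place can shift the number a great deal. Among these compounds, this does not show that the change carries from one core to another, since the only other example puts its methyl at a different place, on the five-membered aromatic ring with 2 nitrogen of the bromo core, and the step from compound 1 to compound 2 cannot be read because both values are limits: the limit of > 100000 nM in this assay, at which 2 of the 4 values shown sit. Among the compounds shown here, the two pairs therefore share a kind of change but neither its place nor its core, and the one readable step stands alone, with no second readable case to confirm or contradict it.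

On these data alone, it remains open whether the large step belongs to methyl itself or whether an ethyl chain, a methoxy group or an amine at the same place would lower the number as well. As far as these compounds go, it also remains open whether the same methyl would act in the same way on a core that carries bromo.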